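Aryl group exchange on the shared core: compound 4

This account rests on a few compounds, and the source may have more. Where it says the series, first, only, none or still open, it means among the compounds named here.

The series varies only the aryl group on the shared core. Compound 1 `CCCS(=O)(=O)Nc1ccc(F)c(C(=O)c2n[nH]c3ncc(-c4ccc(Cl)cc4Cl)cc23)c1F` carries a 2,4-dichlorophenyl, and in an assay for binding affinity to dual specificity mitogen-activated protein kinase kinase 4 (Homo sapiens), read by KINOMEscan, tested at 100 nM (on this read-out lower numbers stand for a stronger effect and higher numbers for a weaker effect at the one concentration tested), compound 1 gives 22%. Compound 2 `CCCS(=O)(=O)Nc1ccc(F)c(C(=O)c2n[nH]c3ncc(-c4cc(Cl)cc(Cl)c4)cc23)c1F` carries a 3,5-dichlorophenyl; in this assay compound 2 gives 73%. Compound 3 `CCCS(=O)(=O)Nc1ccc(F)c(C(=O)c2n[nH]c3ncc(-c4ccc(C(C)(C)C)cc4)cc23)c1F` carries a 4-(tert-butyl)phenyl, and in this assay compound 3 gives 46%, the second highest of the three numbers, standing between the other two.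

The measured steps are a number 51 percentage points higher from compound 1 to compound 2 (beyond the scatter), a number 24 percentage points higher from compound 1 to compound 3 (beyond the scatter) and a number 27 percentage points lower from compound 2 to compound 3 (beyond the scatter); every exchange of the aryl group so far moved the read-out beyond the scatter.

Compound 4 `CCCS(=O)(=O)Nc1ccc(F)c(C(=O)c2n[nH]c3ncc(-c4ccc(C(=O)O)cc4)cc23)c1F` differs from compound 3 by carboxy in place of tert-butyl on an aromatic carbon. The two steps ending at compound 3, a number 24 percentage points higher from compound 1 to compound 3 (beyond the scatter) and a number 27 percentage points lower from compound 2 to compound 3 (beyond the scatter), bear on it most: each exchanges the aryl group at the same place, and each was modest. Among the measured compounds shown here, no measured step involves a carboxy, so the sign of the coming step cannot be read from the data; the middle of the estimate therefore stays near compound 3 while the range spans the steps seen. For compound 4 in this assay the expected value is 50%, with a range from 25% to 80%. This means an expected step of a number 4 percentage points higher from compound 3 to compound 4 (within the scatter), within the scatter as a middle but with either direction open.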

Compound 4, a percentage reported as activity, at one concentration (the size of the read-out at that concentration, not a potency): 0.1%
Compound 4: the middle estimate sits 49.9 percentage points above what was measured; the whole stated range lies above it.
By their numbers in this assay, from the lowest: compound 4; then compound 1; then compound 3; then compound 2.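

In this assay, carboxy in place of tert-butyl on the aromatic carbon gives a number 45.9 percentage points lower from compound 3 to compound 4 (beyond the scatter), so a group with a hydrogen-bond donor and acceptor at this place, with one heavy atom fewer, is compatible with a very low read-out. Among the compounds shown here, the 4-carboxyphenyl also stands apart from both dichlorophenyl groups, with a number 72.9 percentage points lower from compound 2 to compound 4 (beyond the scatter) and a number 21.9 percentage points lower from compound 1 to compound 4 (beyond the scatter), which makes compound 4 the lowest of the four and shows that the best aryl group among the earlier compounds, the 2,4-dichlorophenyl, did not mark the limit at this position. Nothing available here explains why the carboxy exchange moves the read-out this far.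

On these data alone, whether the step belongs to the carboxy itself remains open, since a methyl ester, a primary amide or an aminomethyl group at the same place could separate the carboxy from other groups of similar size. Also open is whether the order of these compounds would hold as potencies, given that each read-out comes from a single concentration.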